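Moving the Trifluoromethyl Group Around on a Phenol-Bearing Core

A few compounds are considered here, and "the series" means these few. Any claim that something is new, unique, unknown or untested is made for them only; others in the source may bear on it.

Measured so far in a functional assay on HCT-15 cells (Homo sapiens) for inhibition; a lower number here means a stronger inhibitor, a higher number a weaker inhibitor:
compound 1, `Oc1cccc(-c2cc(-c3cccc(F)c3)cc(-c3ccccc3O)n2)c1`, reaches only the assay limit of > 50000 nM.
compound 2, `Oc1ccccc1-c1cc(-c2cccc(C(F)(F)F)c2)cc(-c2ccccc2O)n1`, likewise reaches only the assay limit of > 50000 nM.
compound 3, `Oc1cccc(-c2cc(-c3ccccc3C(F)(F)F)cc(-c3ccccc3O)n2)c1`, gives 9010 nM.

Among the measured compounds shown here, compound 3 therefore stands alone as the single real number in this assay; the two other values are limits, not measurements. The step from compound 1 to compound 3, an at least 5.5-fold lower number from compound 1 to compound 3 (0.74 log units; beyond the scatter), moved away from the limit of > 50000 nM in this assay, at which 2 of the 3 values shown sit, when a 2-(trifluoromethyl)phenyl group took the place of a 3-fluorophenyl group.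

Compound 4, `Oc1cccc(-c2cc(-c3cccc(C(F)(F)F)c3)cc(-c3ccccc3O)n2)c1`, differs from compound 3 in one place: 3-(trifluoromethyl)phenyl in place of 2-(trifluoromethyl)phenyl on an aromatic carbon. For the measured compounds named here, the only measured step that bears on this position is the one from compound 1 to compound 3, an at least 5.5-fold lower number from compound 1 to compound 3 (0.74 log units; beyond the scatter), and it ran from a limit to a number. Compound 2 carries the same 3-(trifluoromethyl)phenyl group as compound 4, though among two 2-hydroxyphenyl groups, and shows only a limit. The step from compound 3 to compound 4 is thus expected to run the other way, toward a weaker inhibitor, by about a 4.4-fold higher number from compound 3 to compound 4 (0.65 log units; beyond the scatter). Compound 4 is estimated at 40000 nM, within a range from 9000 nM to 150000 nM, with a real chance that only a limit is reported.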

Compound 4, half-maximal inhibitory concentration: 6460 nM
The estimate for compound 4 lay 6.2-fold (0.79 log units) above the measured number, and the stated range ends above it.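

In this assay, shifting the trifluoromethyl group on this phenyl ring gives no difference that can be read: a 1.4-fold lower number from compound 3 to compound 4 (0.14 log units; within the scatter). The position of the group on that ring therefore makes no visible difference between these two compounds, while the choice of substituent and the hydroxyl placement elsewhere on the core do: with the substituent's ring position held, trifluoromethyl in place of fluoro gives an at least 7.7-fold lower number from compound 1 to compound 4 (0.88 log units; beyond the scatter), and with the same 3-(trifluoromethyl)phenyl group in place, 3-hydroxyphenyl in place of 2-hydroxyphenyl gives an at least 7.7-fold lower number from compound 2 to compound 4 (0.88 log units; beyond the scatter). Both of these larger steps start from a limit rather than a number, so their full size stays unknown: the limit of > 50000 nM in this assay, at which 2 of the 4 values shown sit.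

From the compounds shown here alone, whether the trifluoromethyl group itself is needed remains open, as a chlorine or a methoxy group on this phenyl ring could give a number like those of compound 3 and compound 4, or could fall back to the limit. Also open, going by these compounds, is whether an amine or a carboxylic acid in place of the hydroxyl of the 3-hydroxyphenyl group would keep this level of inhibition.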